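Swapping a nitrile for a carboxylic acid on a shorter chain

The compounds below may be only part of what the source reports. "The series", "measured", "known", "first", "only" and "open" are said of these compounds alone.

For the measured compounds named here, compound 2 `CCc1cc(C(C)=O)c(O)cc1OCCCCCCC(C)(C)C#N` gives 11% in an assay on isolated protein for binding affinity to leukotriene B4 receptor (Homo sapiens), tested at 0.1 uM (a higher number here means more inhibition at the concentration tested (going by the name of the read-out), a lower number less inhibition), the lower of the two numbers measured so far, yet within the scatter of compound 1 `CCc1cc(C(C)=O)c(O)cc1OCCCCCC(C)(C)C#N`, which gives 17%; the step of a number 6 percentage points lower from compound 1 to compound 2 (within the scatter) stays within the scatter. Compound 3 `CCc1cc(C(C)=O)c(O)cc1OCCCC(C)(C)C(=O)O` differs from compound 2 by 1-carboxy-1-methylethyl in place of 4-cyano-4-methylpentyl on a saturated chain carbon, three bonds along the chain from an oxygen on an aromatic ring. Going by the values given here, the only measured step, a number 6 percentage points lower from compound 1 to compound 2 (within the scatter), changed chain length alone, so it bears only loosely on exchanging a cyano group for a carboxy group on a shorter chain, and no step beyond the scatter is expected. Compound 3 is therefore estimated at 14%, between 0% and 35%. This expectation means a step of a number 3 percentage points higher from compound 2 to compound 3 (within the scatter).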

Compound 3, a percentage reported as inhibition, at one concentration (the size of the read-out at that concentration, not a potency): 12%
Compound 3: the middle estimate sits 2 percentage points above what was measured, within the range that was stated.
By their numbers in this assay, from the lowest: compounds 2, 3 and 1 (each within the scatter of the next).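

In this assay, putting 1-carboxy-1-methylethyl in place of 4-cyano-4-methylpentyl gives a number 1 percentage points higher from compound 2 to compound 3 (within the scatter), and putting it in place of 3-cyano-3-methylbutyl gives a number 5 percentage points lower from compound 1 to compound 3 (within the scatter). At this place, a carboxylic acid on a shorter chain therefore reads the same as either nitrile on a longer chain. No available evidence bears on this result.

Both steps change the end group and the chain length together, leaving their separate contributions open. A carboxylic acid on a longer chain, or a nitrile on the shorter chain, would separate them.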